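A few compounds are considered here, and "the series" means these few. Any claim that something is new, unique, unknown or untested is made for them only; others in the source may bear on it.

Measured compounds in the series:
compound 1 `Cc1n[nH]cc1-c1cccc2c1CCC2c1ncc[nH]1` — 91%
compound 2 `c1ccc(-c2cccc3c2CCC3c2ncc[nH]2)nc1` — 53%
compound 3 `COc1c(C)ccc2c1CCC2c1ncc[nH]1` — 40%

In a functional assay on CHO cells for agonist activity at Alpha-1A adrenergic receptor (Homo sapiens), read by FLIPR and calcium flux (on this read-out higher numbers stand for larger maximal responses and lower numbers for smaller maximal responses), compound 2 gives 53%, the second highest of the three numbers: compound 3 lies lower at 40%, beyond the scatter, and compound 1 lies higher at 91%, also beyond the scatter. Among the compounds with values here, the one step between neighbours, a number 38 percentage points lower from compound 1 to compound 2 (beyond the scatter), replaces one aromatic ring with another at the same aromatic carbon and is large.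

Compound 4 `CCCS(=O)(=O)Nc1cccc2c1CCC2c1ncc[nH]1` is not yet measured. It differs from compound 2 as follows: (propylsulfonyl)amino in place of pyridin-2-yl on an aromatic carbon. No measured step exchanges an aromatic ring for a non-ring substituent bearing a hydrogen-bond donor at this carbon, so the step to compound 4 is not covered by any step shown; the single step of a number 38 percentage points lower from compound 1 to compound 2 (beyond the scatter) only indicates that substitution at this carbon can move the maximal response by a large amount. The direction for compound 4 is open. The estimate for compound 4 is 60%, range 35% to 90%, which is expected to mean a step of a number 7 percentage points higher from compound 2 to compound 4 (within the scatter) that may stay within the scatter.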

Compound 4, largest response reached (Emax), in percent of the reference or control that the assay uses: 54%
For compound 4 the middle estimate is 6 percentage points above the measured one, and the stated range covers the measured number.
By their numbers in this assay, from the lowest: compound 3; then compounds 2 and 4 (each within the scatter of the next); then compound 1.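

In this assay, replacing pyridin-2-yl with (propylsulfonyl)amino on this aromatic carbon gives a number 1 percentage points higher from compound 2 to compound 4 (within the scatter), so among these compounds a response of this size does not depend on an aromatic ring at this carbon. The 3-methyl-1H-pyrazol-4-yl group remains apart from both replacements: a number 37 percentage points lower from compound 1 to compound 4 (beyond the scatter) is a large step of about the same size as a number 38 percentage points lower from compound 1 to compound 2 (beyond the scatter), and two very different groups therefore end at the same level. Nothing available explains why these two groups match or why compound 1 stands apart.

Still open, on these data alone, is whether the sulfonyl group or the propyl chain matters, which a methylsulfonylamino or butylsulfonylamino group at this carbon would test. It is also unclear whether the high response needs the pyrazole ring itself, which an unsubstituted pyrazol-4-yl or an imidazole ring could address.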